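The compounds below may be only part of what the source reports. "The series", "measured", "known", "first", "only" and "open" are said of these compounds alone.

Compound 1 `COCc1ccccc1C1Cc2nccn2C1` — 77%
Compound 2 `COc1cccc(C2CCc3nc[nH]c3C2)c1` — 60%
Compound 3 `c1ccc(C2Cc3nccn3C2)cc1` — 80%; 74%; 25%; 85% (4 entries)

In a functional assay on CHO cells for agonist activity at Alpha-1A adrenergic receptor (Homo sapiens), read by FLIPR and calcium flux (on this read-out higher numbers stand for larger maximal responses and lower numbers for smaller maximal responses), compound 1 gives 77%, the highest of the two single numbers; compound 2 gives 60%, a value lower by more than the usual scatter. Compound 3 has no single number, only a wide spread across its repeats, as shown by the several entries of compound 3 in this assay, 80%; 74%; 25%; 85% (4 entries). Compound 4 `NC(=O)c1ccccc1C1Cc2nccn2C1` is the next compound and differs from compound 1 by carbamoyl in place of methoxymethyl on an aromatic carbon. For the measured compounds named here, no pair of measured compounds shows this kind of step, so the account rests on compound 1 alone; given the wide spread for compound 3, a change either way that stays within the scatter is expected. Compound 4 is therefore estimated at 70%, between 45% and 90%, a step of a number 7 percentage points lower from compound 1 to compound 4 (within the scatter) that is expected to stay near the scatter.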

Compound 4, largest response reached (Emax), in percent of the reference or control that the assay uses: 87%
For compound 4 the middle estimate is 17 percentage points below the measured one; low and high end bracket the measured number.
By their numbers in this assay, from the lowest: compound 2; then compounds 1 and 4 (each within the scatter of the next).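

Replacing methoxymethyl with carbamoyl on this aromatic carbon gives, in this assay, a number 10 percentage points higher from compound 1 to compound 4 (within the scatter), so this position keeps a large maximal response when a hydrogen-bond donor and a double bond outside aromatic rings enter. For the compounds shown here, this is the first step at this position, and it shows no change beyond the scatter. Repeats of compound 3 spread widely, which limits how much a single step can carry: the several entries of compound 3 in this assay, 80%; 74%; 25%; 85% (4 entries)

From the compounds shown here alone, it remains open whether an amine, a carboxylic acid or a longer chain on this carbon would keep the response. Going by these compounds, it is also open whether carbamoyl would do the same on the core of compound 2.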